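The source may hold more compounds than are shown below. What is called first, only, known or untested is meant among the compounds shown, and "the series" means these compounds.

Three compounds have been measured in a functional assay on K562 cells (Homo sapiens) for cytotoxicity, read by ELISA, with a stated time of 4 days; a higher number here means a weaker inhibitor, a lower number a stronger inhibitor:

Compound 1 `Cc1ccsc1-c1cc(-c2ccco2)cc(-c2ccccc2Cl)n1`: 25400 nM
Compound 2 `Clc1ccc(-c2cc(-c3ccoc3)cc(-c3ccco3)n2)s1`: 16200 nM
Compound 3 `Cc1cccc(-c2cc(-c3ccoc3)cc(-c3ccc(Cl)s3)n2)c1`: 13700 nM

In this assay, compound 3 lies within the scatter of both compound 1 and compound 2, so these three values cannot be ranked. The next compound, compound 4 `Clc1cccc(-c2cc(-c3ccoc3)cc(-c3ccc(Cl)s3)n2)c1`, keeps everything in compound 3 except one group, with 3-chlorophenyl in place of 3-methylphenyl: chloro in place of methyl on an aromatic carbon.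

Going by the values given here, no measured pair shows this exchange directly. Among the compounds with values here, the only measured step that bears on it is a 1.2-fold lower number from compound 2 to compound 3 (0.07 log units; within the scatter), which replaced a whole group at the same place and left the value within the scatter. Since the exchange in compound 4 is smaller, no change beyond the scatter is expected, and no direction can be supported. The estimated step is a 1.1-fold lower number from compound 3 to compound 4 (0.04 log units; within the scatter). For compound 4, the expected value is 12500 nM, with an estimated range from 6000 nM to 25000 nM.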

Compound 4, half-maximal inhibitory concentration: 22100 nM
Compound 4: middle estimate off by 1.8-fold (0.25 log units), on the low side; measured number inside the range.
By their numbers in this assay, from the lowest: compounds 3, 2, 4 and 1 (each within the scatter of the next).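

At this position, on an aromatic carbon of a six-membered aromatic ring of carbon only, meta to a large group, this assay now has its first direct exchange of chloro for methyl, and it gives a 1.6-fold higher number from compound 3 to compound 4 (0.21 log units; within the scatter) and so does not separate the two groups. The larger replacement of furan-2-yl by 3-chlorophenyl gives a 1.4-fold higher number from compound 2 to compound 4 (0.13 log units; within the scatter) and likewise stays within the scatter, as did the earlier replacement by 3-methylphenyl, which gave a 1.2-fold lower number from compound 2 to compound 3 (0.07 log units; within the scatter) and so the three groups at this place cannot be ranked. No evidence is available that bears on these results.

On these data alone, whether any group at this place can move the number beyond the scatter remains open. An amine or a carboxylic acid on the same aromatic carbon would test this, since all three groups compared here are free of either.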